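This account rests on a few compounds, and the source may have more. Where it says the series, first, only, none or still open, it means among the compounds named here.

Working notes on the acid series. In a physicochemical assay for solubility, read by nephelometry, measured as kinetic solubility, with a stated time of 30 min, at pH 2.0 (a lower number here means a less soluble compound, a higher number a more soluble compound), compound 1 (`O=C(O)COc1ccc([C@H]2CC[C@]3(CC2)OOC2(O3)C3CC4CC2CC(C3)C4O)cc1`) gives 25 ug/mL. Compound 2 (`O=C(O)COc1ccc([C@H]2CC[C@]3(CC2)OOC2(O3)C3CC4CC2CC(C3)C4=O)cc1`) gives 50 ug/mL in this assay, and this number lies within the scatter of the value for compound 1, so the two stand level. Compound 3 (`O=C(O)CNC(=O)COc1ccc([C@H]2CC[C@]3(CC2)OOC2(O3)C3CC4CC(C3)CC2C4)cc1`) reports < 3.1 ug/mL, which is a limit of the assay and not a number.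

The step under consideration leads from compound 1 to compound 4 (`O=C(O)COc1ccc([C@H]2CC[C@]3(CC2)OOC2(O3)C3CC4CC(C3)CC2C4)cc1`), which has not yet been measured: hydrogen in place of hydroxy on a saturated ring carbon. In words, this is hydrogen in place of hydroxy on a saturated ring carbon. For the measured compounds named here, no measured pair isolates this change, so the expectation has no direct precedent and is a judgement.

A fall beyond the scatter is expected in this assay. Compound 1 at 25 ug/mL has room for such a fall. The expected size of the move is a 3.1-fold lower number from compound 1 to compound 4 (0.49 log units; beyond the scatter). A reading at the limit of < 3.1 ug/mL in this assay, at which 1 of the 3 values shown sits, remains possible for compound 4, and the chance of that outcome is not small. The estimated value for compound 4 is 8 ug/mL, with an expected range from 3 ug/mL to 25 ug/mL.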

Compound 4, solubility: 6.3 ug/mL
Compound 4: middle estimate off by 1.3-fold (0.10 log units), on the high side, within the range that was stated.
By their numbers in this assay, from the lowest: compound 4; then compounds 1 and 2 (each within the scatter of the next). At a limit, below all of these: compound 3.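

For the compounds shown here, with hydroxy on this saturated ring carbon replaced by hydrogen, the position now has a measured single-place step in this assay: a 4.0-fold lower number from compound 1 to compound 4 (0.60 log units; beyond the scatter), the first step that isolates this change and one that lies clear of the scatter. Compound 3 stands at a limit of the assay, which is not a number: the limit of < 3.1 ug/mL in this assay, at which 1 of the 4 values shown sits. The step in which hydroxy takes the place of (carboxymethyl)amino on a carbonyl carbon reads as an at least 2.0-fold higher number from compound 3 to compound 4 (0.30 log units; that floor lies within the scatter), so it sets only a floor, and that floor does not separate the two compounds.

The compounds shown leave open how an amine or a methoxy group on the same saturated ring carbon would read in this assay, set against hydroxy in compound 1 and hydrogen in compound 4. They also leave open whether the step from hydroxy to hydrogen keeps its size with a longer chain in place of the carboxymethyl ether, as a single pair gives one reading of this change on one core.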